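Swapping an oxazole for a pyrazole on the shared core

This account rests on a few compounds, and the source may have more. Where it says the series, first, only, none or still open, it means among the compounds named here.

Of the compounds shown here, two with the same core have been tested so far. Compound 1 `CC1(C)CC(NC(=O)c2ccc(Nc3ncc([N+](=O)[O-])c(NC4CCCC4)n3)cc2)CC(C)(C)N1[O]` gives 55600 nM in a functional assay on HeLa cells (Homo sapiens) for antiproliferative activity, read by MTT assay, with a stated time of 48 h; a lower number here means a stronger inhibitor, a higher number a weaker inhibitor. Within the data shown here, compound 2 `Cc1cc(Nc2nc(Nc3ccc(C(=O)NC4CC(C)(C)N([O])C(C)(C)C4)cc3)ncc2[N+](=O)[O-])no1` gives 7360 nM in this assay, the lowest of the two numbers; the only neighbour is compound 1, and the step of a 7.6-fold lower number from compound 1 to compound 2 (0.88 log units; beyond the scatter) is the single measured comparison available. Compound 3 `Cc1cc(Nc2nc(Nc3ccc(C(=O)NC4CC(C)(C)N([O])C(C)(C)C4)cc3)ncc2[N+](=O)[O-])n[nH]1` has not yet been measured. Its difference from compound 2 is 5-methyl-1H-pyrazol-3-yl in place of 5-methyl-1,2-oxazol-3-yl on a nitrogen on an aromatic ring: a ring of the same size, with a nitrogen-hydrogen group now in place of the ring oxygen, at the same place on a nitrogen on an aromatic ring. Among the measured compounds shown here, no measured step exchanges one five-membered aromatic ring for another; the step from compound 1 to compound 2 only shows that this place tolerates change and that a flat aromatic ring there gave the stronger inhibitor. The expectation is therefore a small to modest further lowering, a 2.5-fold lower number from compound 2 to compound 3 (0.39 log units; beyond the scatter), with a wide range. Compound 3 is estimated at 3000 nM in this assay, between 600 nM and 15000 nM.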

Compound 3, half-maximal inhibitory concentration: 29100 nM
Compound 3: middle estimate off by 9.7-fold (0.99 log units), on the low side, outside the stated range (above it).
By their numbers in this assay, from the lowest: compound 2; then compounds 3 and 1 (each within the scatter of the next).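

In this assay the two five-membered aromatic rings are not interchangeable. The step of a 4.0-fold higher number from compound 2 to compound 3 (0.60 log units; beyond the scatter) shows that 5-methyl-1H-pyrazol-3-yl in place of 5-methyl-1,2-oxazol-3-yl is enough to move the number beyond the scatter, although both groups have the same count of heavy atoms, so a flat aromatic ring at this place does not by itself give the stronger inhibitor. The step of a 1.9-fold lower number from compound 1 to compound 3 (0.28 log units; within the scatter) stays within the scatter, which means compound 1 and compound 3 cannot be told apart here, and among the three groups shown only the 5-methyl-1,2-oxazol-3-yl of compound 2 stands out; no measurement at hand accounts for the difference between the two rings.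

With only three groups shown, it remains open whether the ring oxygen of compound 2 or the ring nitrogen-hydrogen of compound 3 matters more for this difference. A pyrazole with a methyl group on that ring nitrogen, or a 5-methylfuran ring, would help to separate the two, and a plain phenyl ring would show how far the result depends on the ring hetero atoms at all.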